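The source may report more compounds than this note shows. Statements on the series, on what has been measured and on what is new or still open speak of the compounds shown alone.

Measured so far:
compound 1 `COc1ccc(C(=O)/C=C/c2ccc(N(C)C)cc2)c2c1C=CC(C)(C)O2`: 3500 nM
compound 2 `COc1ccc(C(=O)/C=C/c2ccc3ccccc3c2)c2c1C=CC(C)(C)O2`: 3670 nM
compound 3 `COc1ccc(C(=O)/C=C/c2ccc(OC)c(OC)c2OC)c2c1C=CC(C)(C)O2`: > 10000 nM

In a functional assay on K562 cells (Homo sapiens) for antiproliferative activity, read by MTT assay, with a stated time of 24 h (a higher number here means a weaker inhibitor, a lower number a stronger inhibitor), compound 1 gives 3500 nM, the lowest of the two numbers recorded. Compound 2 gives 3670 nM in this assay, which sits within the scatter of compound 1, so the two cannot be ordered. Compound 3 sits at the limit of > 10000 nM in this assay, at which 1 of the 3 values shown sits, so its result is a limit and not a number. Among the measured compounds shown here, no measured pair differs in only one place, so no step size is anchored.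

Compound 4 `COc1ccccc1/C=C/C(=O)c1ccc(OC)c2c1OC(C)(C)C=C2` is still to be measured in this assay. Relative to compound 1 the change is 2-methoxyphenyl in place of 4-(dimethylamino)phenyl on a double-bonded chain carbon bound to a double-bonded chain carbon. The step from compound 1 to compound 4 is expected to be a 1.4-fold higher number from compound 1 to compound 4 (0.15 log units; within the scatter), toward a weaker inhibitor, and it may not exceed the scatter. The direction is weighed against compound 3, whose result in this assay is a limit, > 10000 nM. Compound 4 is estimated at 5000 nM, within a range from 2500 nM to 12000 nM, with a real chance that only a limit is returned.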

Compound 4, half-maximal inhibitory concentration: > 10000 nM
Compound 4: no number, only a limit (the forecaster's own chance of this, stated with the estimate: 30%); at least 2.0-fold (0.30 log units) between middle value and limit.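

In this assay, the series now has its first anchored step, an at least 2.8-fold higher number from compound 1 to compound 4 (0.45 log units; beyond the scatter). With the shared core unchanged, the swap of 4-(dimethylamino)phenyl for 2-methoxyphenyl on a double-bonded chain carbon bound to a double-bonded chain carbon is enough to move the read-out beyond the scatter, so this place is sensitive to the identity of the aryl group. Compound 4 returns a limit and not a number, so the step has a lower bound only, and the full size of the change stays unknown: the limit of > 10000 nM in this assay, at which 2 of the 4 values shown sit.

The loss of 4-(dimethylamino)phenyl and the entry of 2-methoxyphenyl come together in this one step, and the data cannot tell their contributions apart. An unsubstituted phenyl at this place would give a reference point for both groups.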